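The source may hold more compounds than are shown below. What is called first, only, known or untested is meant among the compounds shown, and "the series" means these compounds.

Measured in a functional assay on Vero cells (Chlorocebus sabaeus) for inhibition; on this read-out lower numbers stand for stronger inhibition and higher numbers for weaker inhibition:
- Compound 1 `COc1cc(/C=C/C(=O)c2cccc(NC(=O)c3cccs3)c2)ccc1O`: 3.98 ug/mL
- Compound 2 `COc1cc(/C=C/C(=O)c2cccc(NC(=O)c3ccc(Cl)cc3Cl)c2)ccc1O`: 27.2 ug/mL
- Compound 3 `COC(=O)C(=O)Nc1cccc(C(=O)/C=C/c2ccc(O)c(OC)c2)c1`: 3.55 ug/mL

Compound 3 stands level with compound 1, within the scatter, and apart from compound 2. Compound 4 `CCOC(=O)C(=O)Nc1cccc(C(=O)/C=C/c2ccc(O)c(OC)c2)c1` differs from compound 3 by methyl in place of hydrogen on a saturated chain carbon bound to an oxygen next to a carbonyl group, so methoxycarbonyl becomes ethoxycarbonyl. Going by the values given here, no measured step makes this change itself. The nearest evidence is on the same carbonyl carbon, where a far larger exchange gave a 1.1-fold lower number from compound 1 to compound 3 (0.05 log units; within the scatter), while the 2,4-dichlorophenyl group gave a 6.8-fold higher number from compound 1 to compound 2 (0.83 log units; beyond the scatter) and a 7.7-fold lower number from compound 2 to compound 3 (0.88 log units; beyond the scatter). For so small an addition, no shift beyond the scatter is expected, and the estimated step is a 1.1-fold higher number from compound 3 to compound 4 (0.03 log units; within the scatter). Compound 4 is expected at 3.8 ug/mL, with an estimated range of 1.8 ug/mL to 8.5 ug/mL.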

Compound 4, half-maximal inhibitory concentration: > 50 ug/mL
Compound 4: no number, only a limit (the forecaster's own chance of this, stated with the estimate: 3%); middle value at least 13-fold (1.11 log units) from the limit.
By their numbers in this assay, from the lowest: compounds 3 and 1 (each within the scatter of the next); then compound 2. At a limit, above all of these: compound 4.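

Compound 4 gives a limit of the assay, not a number: the limit of > 50 ug/mL in this assay, at which 1 of the 4 values shown sits.

Read against that limit, this carbonyl carbon is far less forgiving than the earlier compounds suggested: one added methyl gave an at least 14-fold higher number from compound 3 to compound 4 (1.14 log units; beyond the scatter) on going from methoxycarbonyl to ethoxycarbonyl. Ethoxycarbonyl also gave an at least 12-fold higher number from compound 1 to compound 4 (1.09 log units; beyond the scatter) against thiophen-2-yl, whereas an at least 1.8-fold higher number from compound 2 to compound 4 (0.26 log units; that floor lies within the scatter) leaves compound 4 not clearly separated from the 2,4-dichlorophenyl compound.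

On these data alone, how far compound 4 lies beyond its limit remains open. So does whether a longer chain such as propoxycarbonyl, or a carboxylic acid, would fall with compound 3 or with compound 4.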